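Allyl versus butyl carbamate on the selenocyanate series

This account rests on a few compounds, and the source may have more. Where it says the series, first, only, none or still open, it means among the compounds named here.

Measured compounds:
compound 1 `CC(C)COC(=O)Nc1ccc([Se][Se]c2ccc(NC(=O)OCC(C)C)cc2)cc1` — 39800 nM
compound 2 `CCCCOC(=O)Nc1ccc([Se]C#N)cc1` — 27900 nM

Two compounds have been run in a functional assay on CCRF-CEM cells (Homo sapiens) for cytotoxicity, read by MTT assay, with a stated time of 72 h; on this read-out lower numbers stand for stronger inhibition of growth and higher numbers for weaker inhibition of growth. Compound 1 carries the diselenide-linked pair of carbamate-substituted rings and gives 39800 nM. Compound 2 carries a single selenocyanate-bearing ring with a butyl carbamate and gives 27900 nM. Of the two numbers, compound 2 sits at the low end, but compound 1 stands within the scatter of it, so the two cannot be ordered against each other. Within the data shown here, no pair of measured compounds differs in one place, so no computed step is available in this assay.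

Compound 3 `C=CCOC(=O)Nc1ccc([Se]C#N)cc1` is not yet measured. It differs from compound 2 by vinyl in place of propyl on a saturated chain carbon bound to an oxygen next to a carbonyl group, which read one bond further out is butyl to allyl, butoxy to allyloxy. Among the measured compounds shown here, with no measured step to lean on, the expected change in this assay from compound 2 to compound 3 is none beyond the scatter, estimated as a 1.0-fold higher number from compound 2 to compound 3 (0.00 log units; within the scatter). Compound 3 is therefore expected to give about 28000 nM, within a range of 12000 nM to 65000 nM.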

Compound 3, concentration for total growth inhibition: 38100 nM
For compound 3 the middle estimate is 1.4-fold (0.13 log units) below the measured one; the measured number falls inside the stated range.
By their numbers in this assay, from the lowest: compounds 2, 3 and 1 (each within the scatter of the next).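

In this assay, vinyl in place of propyl on a saturated chain carbon bound to an oxygen next to a carbonyl group, read one bond further out as butyl to allyl, gives a 1.4-fold higher number from compound 2 to compound 3 (0.14 log units; within the scatter). Among these compounds, this is the first step that can be read in one place, and it shows that at this position, in the selenocyanate compounds, a double bond outside aromatic rings can replace the saturated end of the chain with no change that can be told from the scatter. No supporting measurement bears on this result, so the step stands as an observation without an explanation.

A single step says nothing about how far this position tolerates change, and a much longer chain such as octyl, a benzyl group or a terminal amine on the carbamate chain could still separate from the butyl and allyl compounds. On these data alone, compound 1 differs from compound 2 and compound 3 in more than one place, so the contribution of the selenocyanate relative to the diselenide also remains open.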